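Bromo in place of methoxy: compound 3 to compound 4

The compounds below may be only part of what the source reports. "The series", "measured", "known", "first", "only" and "open" are said of these compounds alone.

In a functional assay on MCF7 cells (Homo sapiens) for inhibition, read by MTT assay, with a stated time of 24 h (on this read-out higher numbers stand for weaker inhibition of growth and lower numbers for stronger inhibition of growth), compound 1 (`COc1ccccc1C(=O)n1c(-c2cn(C)c3ccccc23)nc2ccccc21`) gives 32100 nM, compound 2 (`COc1ccc2c(c1)c(-c1nc3ccccc3n1C(=O)c1ccccc1OC)cn2C`) gives 23900 nM and compound 3 (`COc1ccccc1C(=O)n1c(-c2cn(C)c3ccc(Br)cc23)nc2ccccc21`) gives 36200 nM. Compound 3 thus stands within the scatter of both others. Compound 4 (`Cn1cc(-c2nc3ccccc3n2C(=O)c2ccccc2Br)c2cc(Br)ccc21`) differs from compound 3 by bromo in place of methoxy on an aromatic carbon, reading 2-methoxyphenyl to 2-bromophenyl, ortho to a large group. No change at this place has been measured. The nearest evidence is the same exchange elsewhere, a 1.5-fold higher number from compound 2 to compound 3 (0.18 log units; within the scatter), alongside a 1.3-fold lower number from compound 1 to compound 2 (0.13 log units; within the scatter) and a 1.1-fold higher number from compound 1 to compound 3 (0.05 log units; within the scatter). All three stay within the scatter, so no real shift is expected. The expected step is a 1.1-fold lower number from compound 3 to compound 4 (0.05 log units; within the scatter). Compound 4 is estimated at 32000 nM, with an expected range of 15000 nM to 65000 nM.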

Compound 4, concentration for 50% growth inhibition: 73600 nM
The estimate for compound 4 lay 2.3-fold (0.36 log units) below the measured number; the measured number lies above the stated range.
By their numbers in this assay, from the lowest: compounds 2, 1 and 3 (each within the scatter of the next); then compound 4.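

In this assay, going by these compounds alone, the change from 2-methoxyphenyl to 2-bromophenyl, ortho to a large group, gives a 2.0-fold higher number from compound 3 to compound 4 (0.31 log units; beyond the scatter) and is the first step to pass the scatter, towards weaker inhibition of growth. The same exchange at the other place, a 1.5-fold higher number from compound 2 to compound 3 (0.18 log units; within the scatter), stays within the scatter, so the two places do not read alike. Nothing measured here accounts for this difference.

On these data alone, whether an amine or a carboxylic acid at this place would move the number further remains open. So does whether the step holds on the core of compound 1, which lacks the second bromo.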